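Extending the chain of compound 2: working notes

A few compounds are considered here, and "the series" means these few. Any claim that something is new, unique, unknown or untested is made for them only; others in the source may bear on it.

Measured in a functional assay on SW480 cells (Homo sapiens) for antiproliferative activity, read by MTT assay, with a stated time of 48 h; a higher number here means a weaker inhibitor, a lower number a stronger inhibitor:
compound 1 `CCCCCCCC(CCO)n1cnc2c(Cl)ncnc21`: 3630 nM
compound 2 `CCCCCCC[C@H](CCO)n1cnc2c(Cl)ncnc21`: 2930 nM

Within the data shown here, compound 2 stands level with the only other measured compound: the step is a 1.2-fold lower number from compound 1 to compound 2 (0.09 log units; within the scatter), within the scatter. The next structure, compound 3 `CCCCCCCCC[C@H](CCO)n1cnc2c(Cl)ncnc21`, lengthens the chain of compound 2: ethyl in place of hydrogen on a saturated chain carbon, eight bonds along the chain from an aromatic nitrogen. Among the measured compounds shown here, the one measured step bears on this change only weakly. It rests on (the fact that one of compounds 1 and 2 is drawn with a defined configuration and the other without, at the place where they differ), and the chain is the same on both sides of it. For the measured compounds named here, no measured pair varies chain length, so the data give no size or direction for this change. No step beyond the scatter is therefore expected in this assay. The estimated step is a 1.1-fold lower number from compound 2 to compound 3 (0.05 log units; within the scatter). For compound 3 the expected value is 2600 nM, with an estimated range of 1000 nM to 6500 nM.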

Compound 3, half-maximal inhibitory concentration: 1630 nM
Beside the measured number, compound 3's estimate is 1.6-fold (0.20 log units) above it; the measured number falls inside the stated range.
By their numbers in this assay, from the lowest: compounds 3, 2 and 1 (each within the scatter of the next, the first and the last beyond it).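

In this assay, among these compounds, the first pair that varies chain length gives a 1.8-fold lower number from compound 2 to compound 3 (0.25 log units; within the scatter), so ethyl in place of hydrogen on a saturated chain carbon, eight bonds along the chain from an aromatic nitrogen, leaves compound 3 level with compound 2. This position therefore accepts the added two carbons with no change beyond the scatter, a point the stereo comparison of compounds 1 and 2 could not address. Nothing available on these compounds accounts for this result.

On these data alone, a single pair gives no trend with chain length, so it remains open how the series behaves with a longer chain than that of compound 3 or a shorter one than that of compound 2. Also open, as far as these compounds go, is whether a phenyl group or a carboxylic acid at this same saturated chain carbon would produce a step beyond the scatter.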